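From chloromethyl to isothiocyanate on a selenazole core

The compounds below may be only part of what the source reports. "The series", "measured", "known", "first", "only" and "open" are said of these compounds alone.

Compound 1 `CC(=O)Nc1nc(CCl)c[se]1` stands only at a limit: in a functional assay on L1210 cells (Mus musculus) for antiproliferative activity (on this read-out higher numbers stand for weaker inhibition and lower numbers for stronger inhibition), compound 1 gives > 100000 nM, which is a limit of the assay and not a number, as the line the limit of > 100000 nM in this assay, at which 1 of the 2 values shown sits, records. Compound 2 `O=C(Nc1nc(CN=C=S)cs1)c1ccc(Cl)c(Cl)c1` gives 820 nM in this assay. Compound 3 `CC(=O)Nc1nc(CN=C=S)c[se]1` differs from compound 1 by a group of 3 heavy atoms (1 carbon, 1 nitrogen, 1 sulfur; no ring) in place of one chlorine atom, on a saturated chain carbon bound to an aromatic carbon. A step towards stronger inhibition, beyond the scatter, is expected in this assay, since compound 2 gives 820 nM. Compound 3 is estimated at 15000 nM, between 1500 nM and 100000 nM, a step of an at least 6.6-fold lower number from compound 1 to compound 3 (0.82 log units; beyond the scatter).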

Compound 3, half-maximal inhibitory concentration: 30000 nM
Estimate against measurement, compound 3: 2.0-fold (0.30 log units) below, and the stated range covers the measured number.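

In this assay, replacing chloro with isothiocyanate on a saturated chain carbon bound to an aromatic carbon, with the rest of the structure unchanged, gives an at least 3.3-fold lower number from compound 1 to compound 3 (0.52 log units; beyond the scatter), so this place responds to the change. The full size of this step stays unknown because one end of it is a limit of the assay and not a number: the limit of > 100000 nM in this assay, at which 1 of the 3 values shown sits.

The compounds shown leave open whether an amine or a hydroxyl group at this place would also lower the number, and whether a longer chain carrying the isothiocyanate would keep the step.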